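A Longer Chain Toward the Phenylcarbamoyl Group

The compounds below may be only part of what the source reports. "The series", "measured", "known", "first", "only" and "open" are said of these compounds alone.

Three compounds have been measured in a physicochemical assay for lipophilicity; on this read-out higher numbers stand for higher lipophilicity and lower numbers for lower lipophilicity:
compound 1 `CCCCCc1cccc2c(C3=C(Br)C(=O)NC3=O)c(-c3ccccc3)[nH]c12` with 4.11;
compound 2 `CCCCCCc1ccc2[nH]c(-c3cccc(OC)c3)c(C3=C(Br)C(=O)NC3=O)c2c1` with 4.26;
compound 3 `O=C(CCCc1[nH]c2ccccc2c1C1=C(Br)C(=O)NC1=O)Nc1ccccc1` with 2.56.

Compound 3 stands lowest of the three. Its nearest neighbour is compound 1, whose number lies higher by a gap beyond the scatter, and compound 2 lies higher still, again beyond the scatter. Among the compounds with values here, no pair among the three differs in only one place, so no single step can be read off between them.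

Compound 4 `O=C(CCCCc1[nH]c2ccccc2c1C1=C(Br)C(=O)NC1=O)Nc1ccccc1` is not yet measured. It differs from compound 3 in one place: (phenylcarbamoyl)methyl in place of phenylcarbamoyl on a saturated chain carbon, three bonds along the chain from an aromatic carbon. The change lengthens the saturated chain by one unit while keeping the same ring, the same donor and the same acceptor.

For a change of this kind in this assay, one would expect a small rise, most likely close to or just beyond the scatter, rather than a fall or no change. The estimate for compound 4 is therefore 2.95, within a range of 2.55 to 3.35. That estimate means a step of a number 0.39 log units higher from compound 3 to compound 4 (beyond the scatter), expected to be upward.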

Compound 4, partition coefficient: 2.56
Compound 4: middle estimate off by 0.39 log units, on the high side, and the stated range covers the measured number.
By their numbers in this assay, from the lowest: compounds 3 and 4 (each within the scatter of the next); then compounds 1 and 2 (each within the scatter of the next).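

Replacing phenylcarbamoyl with (phenylcarbamoyl)methyl on a saturated chain carbon, three bonds along the chain from an aromatic carbon, gives no change at the digits printed from compound 3 to compound 4 (within the scatter) in this assay. Within the data shown here, this is the first step that can be read at a single place, which the earlier compounds could not offer, and it shows that at this position the entering group, with 10 heavy atoms against 9 and the same counts of donors and acceptors, leaves the number where it stood. Nothing available here accounts for this outcome.

The compounds shown rest on a single step, so they leave open whether a still longer chain ending in the same phenylcarbamoyl group would also give a number within the scatter of compound 3. They also leave open what would happen if an amine or a carboxylic acid took the place of phenylcarbamoyl on this chain, since every chain end compared here carries the same phenylcarbamoyl group.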